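The source may report more compounds than this note shows. Statements on the series, on what has been measured and on what is new or still open speak of the compounds shown alone.

Four close relatives were compared in an ADME assay on HEK293 cells (Homo sapiens) for cytotoxicity, read by MTT assay, with a stated time of 48 h; on this read-out lower numbers stand for stronger inhibition and higher numbers for weaker inhibition. Compound 1 `CN(c1ccc(NC(=O)c2cc(C(F)(F)F)cc(C(F)(F)F)c2)cc1OCc1cccc(C(F)(F)F)c1)S(=O)(=O)Cc1ccccc1` gives 59800 nM. Compound 2 `CN(c1ccc(NC(=O)c2ccc(C(F)(F)F)cc2C(F)(F)F)cc1OCc1cccc(C(F)(F)F)c1)S(=O)(=O)Cc1ccccc1` gives 176000 nM; how the cores of compound 1 and compound 2 differ is not broken down here. Compound 3 `CN(c1ccc(NC(=O)c2cc(C(F)(F)F)cc(C(F)(F)F)c2)cc1OCc1ccccc1C(F)(F)F)S(=O)(=O)Cc1ccccc1` reaches only a limit of the assay, > 500000 nM, which is the limit of > 500000 nM in this assay, at which 1 of the 3 values shown sits. The change from compound 1 to compound 3 is 2-(trifluoromethyl)phenyl in place of 3-(trifluoromethyl)phenyl on a saturated chain carbon bound to an oxygen on an aromatic ring, and it produced an at least 8.3-fold higher number from compound 1 to compound 3 (0.92 log units; beyond the scatter). Compound 4 `CN(c1ccc(NC(=O)c2ccc(C(F)(F)F)cc2C(F)(F)F)cc1OCc1ccccc1C(F)(F)F)S(=O)(=O)Cc1ccccc1` is made from compound 2 by the same change, (2-(trifluoromethyl)phenyl in place of 3-(trifluoromethyl)phenyl on a saturated chain carbon bound to an oxygen on an aromatic ring). Since compound 2 already starts from 176000 nM and the earlier step was an at least 8.3-fold higher number from compound 1 to compound 3 (0.92 log units; beyond the scatter), the value of compound 4 in this assay is expected to land at 800000 nM within 300000 nM to 3000000 nM. That estimated move corresponds to a 4.5-fold higher number from compound 2 to compound 4 (0.66 log units; beyond the scatter) from compound 2 to compound 4.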

Compound 4, half-maximal inhibitory concentration: > 500000 nM
Compound 4 gave a limit, no number (the forecaster's own chance of this, stated with the estimate: 75%); the middle value lies beyond the limit too.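

In this assay, putting 2-(trifluoromethyl)phenyl in place of 3-(trifluoromethyl)phenyl gave an at least 2.8-fold higher number from compound 2 to compound 4 (0.45 log units; beyond the scatter), so the direction seen on the core of compound 1 held on the core of compound 2. Whether the size of the step carried over as well cannot be read: the same change on two cores in this assay, an at least 8.3-fold higher number (0.92 log units; beyond the scatter) from compound 1 to compound 3 and an at least 2.8-fold higher number (0.45 log units; beyond the scatter) from compound 2 to compound 4; the limit leaves it open whether they differ Compound 3 and compound 4 both give a limit and not a number, so neither step has a known full size: the limit of > 500000 nM in this assay, at which 2 of the 4 values shown sit.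

Only two cores are shown here, so how this change behaves on any other core stays open. Going by these compounds, it also stays open what a nitrile or a carboxylic acid in place of the trifluoromethyl group on the benzyl would do in this assay.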